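Iodo in Place of Chloro: Tolerance Expected to Hold

The source may hold more compounds than are shown below. What is called first, only, known or untested is meant among the compounds shown, and "the series" means these compounds.

Compound 1 `Cc1ccccc1CNCc1cc(=O)c2c(O)c(O)ccc2o1` was examined in an ADME assay on Huh-7 cells (Homo sapiens) for cytotoxicity (a lower number here means that less compound is tolerated, a higher number that more compound is tolerated), where compound 1 gives 52200 nM. Compound 2 `O=c1cc(CNCc2cccc(Cl)c2)oc2ccc(O)c(O)c12` differs from it only in the group carried on the saturated chain carbon bound to the amine nitrogen. In this assay compound 2 reaches only a limit of the assay, > 100000 nM, and not a number; the value of compound 2 in this assay is therefore known only as a range. This is reflected in the limit of > 100000 nM in this assay, at which 1 of the 2 values shown sits. Among the measured compounds shown here, the single measured step, an at least 1.9-fold higher number from compound 1 to compound 2 (0.28 log units; that floor lies within the scatter), is a floor that lies within the scatter.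

Compound 3 `O=c1cc(CNCc2cccc(I)c2)oc2ccc(O)c(O)c12` is not yet measured. It differs from compound 2 by iodo in place of chloro on an aromatic carbon. For the measured compounds named here, no measured step swaps one halogen for another; the only step on record changes the whole aryl group and stays within the scatter. On that basis compound 3 is expected to behave like compound 2, and the step that the limit leaves unreadable from compound 2 to compound 3 is expected to stay within the scatter. Compound 3 is therefore estimated at 120000 nM in this assay, with a range from 50000 nM to 300000 nM, most likely reported again only as a limit.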

Compound 3, half-maximal cytotoxic concentration: > 100000 nM
Compound 3: no number, only a limit (the forecaster's own chance of this, stated with the estimate: 70%); the middle value does not contradict the limit.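

Compound 3 gives > 100000 nM in this assay, which is a limit of the assay and not a number, so iodo in place of chloro on this aromatic carbon does not bring the read-out into the measurable range. The step from compound 2 to compound 3 cannot be read, and the limit now accounts for most of the values in this small set: the limit of > 100000 nM in this assay, at which 2 of the 3 values shown sit. Replacing 2-methylphenyl with 3-iodophenyl gives an at least 1.9-fold higher number from compound 1 to compound 3 (0.28 log units; that floor lies within the scatter), the same floor that 3-chlorophenyl gave, so neither halogen is yet shown to differ from the 2-methylphenyl compound beyond the scatter.

As far as these compounds go, whether compound 2 and compound 3 differ at all in this assay remains open, as does the true size of either step from compound 1. Also open, from the compounds shown here alone, is whether a nitrile or a carboxylic acid in place of the iodo on that aromatic carbon would yield a number rather than a limit, and so show whether the group at this position matters for how much compound the cells tolerate.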